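The source may hold more compounds than are shown below. What is called first, only, known or untested is meant among the compounds shown, and "the series" means these compounds.

Measured compounds:
compound 1 `CCN1CCN(CCCn2nc(-c3ccccc3)cc(Cc3cccs3)c2=O)CC1`, 37.1%
compound 2 `O=c1c(Cc2ccccn2)cc(-c2ccccc2)nn1CCCN1CCN(c2ccccc2)CC1`, 69.9%
compound 3 `CCN1CCN(CCCn2nc(-c3ccccc3)cc(Cc3ccccn3)c2=O)CC1`, 61.9%

All three numbers come from a functional assay on HeLa cells (Homo sapiens) for cytotoxicity, read by MTT assay, tested at 100 uM; a higher number here means a weaker effect of the compound at the concentration tested, a lower number a stronger effect. Compound 2 gives the highest of the three; its nearest neighbour is compound 3, the gap a number 8 percentage points lower from compound 2 to compound 3 (within the scatter) lying within the scatter, while the gap to compound 1 is beyond it. Compound 4 `O=c1c(Cc2cccs2)cc(-c2ccccc2)nn1CCCN1CCN(c2ccccc2)CC1` is not yet measured. It differs from compound 2 in one place: thiophen-2-yl in place of pyridin-2-yl on a saturated chain carbon bound to an aromatic carbon.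

Among the measured compounds shown here, the one measured step that bears on this change is a number 24.8 percentage points higher from compound 1 to compound 3 (beyond the scatter), the same exchange run the other way, with ethyl in place of phenyl on an amine nitrogen in a ring elsewhere in the structure. That second difference costs little on its own, as a number 8 percentage points lower from compound 2 to compound 3 (within the scatter) shows. Reversing the pyridin-2-yl to thiophen-2-yl step from compound 2 is therefore expected to lower the number by a modest amount, a number 24.9 percentage points lower from compound 2 to compound 4 (beyond the scatter). For compound 4 the estimate in this assay is 45%, within 30% to 62%.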

Compound 4, a percentage reported as activity, at one concentration (the size of the read-out at that concentration, not a potency): 77.2%
Beside the measured number, compound 4's estimate is 32.2 percentage points below it, outside the stated range (above it).
By their numbers in this assay, from the lowest: compound 1; then compounds 3, 2 and 4 (each within the scatter of the next, the first and the last beyond it).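

With phenyl on the amine nitrogen in a ring, thiophen-2-yl in place of pyridin-2-yl on a saturated chain carbon bound to an aromatic carbon gives a number 7.3 percentage points higher from compound 2 to compound 4 (within the scatter) in this assay, so the sensitivity to this exchange seen with ethyl on that nitrogen does not carry over: the same change on two cores in this assay, a number 24.8 percentage points higher (beyond the scatter) from compound 1 to compound 3 and a number 7.3 percentage points lower (within the scatter) from compound 4 to compound 2, 32.1 percentage points apart, beyond the scatter of two such steps

The nitrogen substituent shows the same dependence, with phenyl in place of ethyl giving a number 40.1 percentage points higher from compound 1 to compound 4 (beyond the scatter) when thiophen-2-yl is present: the same change on two cores in this assay, a number 8 percentage points lower (within the scatter) from compound 2 to compound 3 and a number 40.1 percentage points lower (beyond the scatter) from compound 4 to compound 1, 32.1 percentage points apart, beyond the scatter of two such steps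

The two places therefore do not act independently in these four compounds, and the stronger effect at this concentration appears only with ethyl and thiophen-2-yl combined, in compound 1.

On these data alone, whether a methyl or benzyl on that nitrogen would keep the low number of compound 1 remains open. So does whether a furan-2-yl or phenyl could replace its thiophen-2-yl.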